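Following Compound 3 to Compound 4 in a Cytotoxicity Series

This account rests on a few compounds, and the source may have more. Where it says the series, first, only, none or still open, it means among the compounds named here.

Compound 1 `NS(=O)(=O)c1cc(-c2nnc(CN3CCN(c4ccc(Cl)cc4)CC3)o2)c(Cl)cc1SCc1ccccc1`: 78000 nM
Compound 2 `Cc1ccc(C)c(N2CCN(Cc3nnc(-c4cc(S(N)(=O)=O)c(SCc5ccccc5)cc4Cl)o3)CC2)c1`: 17000 nM
Compound 3 `CCOC(=O)c1cn(Cc2nnc(-c3cc(S(N)(=O)=O)c(SCc4ccccc4)cc3Cl)o2)nn1`: 108000 nM

In a functional assay on HCT-116 cells (Homo sapiens) for cytotoxicity, read by MTT assay, with a stated time of 72 h (a higher number here means a weaker inhibitor, a lower number a stronger inhibitor), compound 3 gives the highest of the three numbers; compound 1 lies within the scatter of it, while compound 2 sits further away, beyond the scatter. Going by the values given here, the only measured step, a 4.6-fold lower number from compound 1 to compound 2 (0.66 log units; beyond the scatter), concerns the group on the amine nitrogen in a ring and leaves the rest of the shared core untouched. Compound 4 `NS(=O)(=O)c1cc(-c2nnc(/C=C/c3ccccc3)o2)c(Cl)cc1SCc1ccccc1` arises from compound 3 by 2-phenylethenyl in place of (4-(ethoxycarbonyl)-1H-1,2,3-triazol-1-yl)methyl on an aromatic carbon. Among the compounds with values here, no measured step touches this position, so neither size nor direction can be read from compound 1 or compound 2; the expectation rests on the narrow band in which all three numbers fall. Compound 4 is therefore expected near 60000 nM, within a range from 15000 nM to 200000 nM. This corresponds to an expected step of a 1.8-fold lower number from compound 3 to compound 4 (0.26 log units; within the scatter).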

Compound 4, half-maximal inhibitory concentration: 18000 nM
Beside the measured number, compound 4's estimate is 3.3-fold (0.52 log units) above it; low and high end bracket the measured number.
By their numbers in this assay, from the lowest: compounds 2 and 4 (each within the scatter of the next); then compounds 1 and 3 (each within the scatter of the next).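

The aromatic carbon of the five-membered aromatic ring with 2 nitrogen and 1 oxygen proves to be a position that responds in this assay: exchanging (4-(ethoxycarbonyl)-1H-1,2,3-triazol-1-yl)methyl for 2-phenylethenyl gives a 6.0-fold lower number from compound 3 to compound 4 (0.78 log units; beyond the scatter). So a change outside the amine nitrogen in a ring also moves the number beyond the scatter. Nothing at hand accounts for this step. The compounds shown leave open whether the double bond or the six-membered aromatic ring carries the change. A saturated 2-phenylethyl chain or a simple amine at this carbon could separate these possibilities.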